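The source may hold more compounds than are shown below. What is called first, only, known or untested is meant among the compounds shown, and "the series" means these compounds.

Compound 1 `CC1=CC[C@H](C(C)(C)NC(=S)N/N=C/c2cccs2)CC1` is the only one of the two measured compounds with a definite number: in a functional assay on 786-0 cells (Homo sapiens) for inhibition, read by sulforhodamine B assay, with a stated time of 48 h (a higher number here means a weaker inhibitor of growth, a lower number a stronger inhibitor of growth), compound 1 gives 11500 nM. Compound 2 `CC1=CC[C@H](C(C)(C)NC(=S)N/N=C(\C)c2ccccc2)CC1` carries a different group at one end of the shared core. In this assay compound 2 reaches only the limit of the assay, > 100000 nM, so no number is known for it. This reading sits at the limit of > 100000 nM in this assay, at which 1 of the 2 values shown sits. Compound 3 `COc1ccc(/C(C)=N/NC(=S)NC(C)(C)[C@H]2CC=C(C)CC2)cc1` differs from compound 2 by methoxy in place of hydrogen on an aromatic carbon, that is, phenyl to 4-methoxyphenyl. Among the compounds with values here, no measured pair shows this change, and compound 2 offers only a limit as a starting point, so the expected step is a step that the limit leaves unreadable from compound 2 to compound 3, none beyond the scatter, with no firm direction. In this assay compound 3 is therefore expected at 120000 nM, within a range from 30000 nM to 500000 nM, and a reading that again stops at the limit is the more likely outcome.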

Compound 3, concentration for 50% growth inhibition: > 100000 nM
Compound 3: only a limit was reported; the forecaster's own chance of this, stated with the estimate: 65%; the middle value does not contradict the limit.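

Compound 2 and compound 3 both stop at a limit rather than a number, so no step can be read between them, because neither has a definite value: the limit of > 100000 nM in this assay, at which 2 of the 3 values shown sit.

The compounds shown leave open whether methoxy in place of hydrogen on an aromatic carbon changes growth inhibition at all.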